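A few compounds are considered here, and "the series" means these few. Any claim that something is new, unique, unknown or untested is made for them only; others in the source may bear on it.

Measured in an assay on COS-7 cells for inhibition of sodium/nucleoside cotransporter 2 (Homo sapiens), read by scintillation counting; on this read-out higher numbers stand for weaker inhibition and lower numbers for stronger inhibition:
compound 1 `Nc1ncnc2c1nc(NCc1ccc(-c3ccccn3)cc1)n2[C@@H]1O[C@H](CO)[C@@H](O)[C@H]1O` gives 1500 nM
compound 2 `CC(C)Oc1cc(CNc2nc3c(N)ncnc3n2[C@@H]2O[C@H](CO)[C@@H](O)[C@H]2O)ccc1-c1ccccc1` gives 10400 nM
compound 3 `CCOc1cc(-c2ccccc2)ccc1CNc1nc2c(N)ncnc2n1[C@@H]1O[C@H](CO)[C@@H](O)[C@H]1O` gives 5400 nM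

Compound 2 has the highest number of the three in this assay. Its gap to compound 3 lies within the scatter, while its gap to compound 1 lies beyond it. Compound 4 `Nc1ncnc2c1nc(NCc1ccc(-c3ccccc3)c(OCCCCCO)c1)n2[C@@H]1O[C@H](CO)[C@@H](O)[C@H]1O` has not been measured. It differs from compound 2 in one place: 5-hydroxypentyl in place of isopropyl on an oxygen on an aromatic ring. Among the compounds with values here, no measured pair shows this change, so no step for it is known from the data at hand. With nothing to anchor a direction, no step beyond the scatter is expected either way. Compound 4 is therefore estimated at 7000 nM, with a range from 2500 nM to 20000 nM. The estimate means an expected step of a 1.5-fold lower number from compound 2 to compound 4 (0.17 log units; within the scatter), staying within the scatter.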

Compound 4, half-maximal inhibitory concentration: 1600 nM
The estimate for compound 4 lay 4.4-fold (0.64 log units) above the measured number; the measured number lies below the stated range.
By their numbers in this assay, from the lowest: compounds 1 and 4 (each within the scatter of the next); then compounds 3 and 2 (each within the scatter of the next).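

In this assay, the step from isopropyl to 5-hydroxypentyl on this oxygen is a 6.5-fold lower number from compound 2 to compound 4 (0.81 log units; beyond the scatter), the first step read at this place. It shows that this oxygen can carry a much larger group ending in a hydroxyl without the number rising; here it falls. Nothing at hand accounts for this step.

The compounds shown leave open whether the chain length or the terminal hydroxyl goes with the lower number. A plain pentyl group or a 3-hydroxypropyl group on the same oxygen would separate the two.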